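A few compounds are considered here, and "the series" means these few. Any claim that something is new, unique, unknown or untested is made for them only; others in the source may bear on it.

Measured in a functional assay on C6 cells (Rattus norvegicus) for cytotoxicity, read by MTT assay, with a stated time of 24 h, tested at 50 ug/mL; a higher number here means a weaker effect of the compound at the concentration tested, a lower number a stronger effect: compound 1 `Cc1nnc(SCC(=O)N/N=c2/scc(-c3ccccc3)n2-c2ccccc2)s1` gives 63.9%; compound 2 `Cc1nnc(SCC(=O)N/N=c2/scc(-c3ccc(Cl)cc3)n2-c2ccccc2)s1` gives 37.9%; compound 3 `Cc1ccc(-c2cs/c(=N/NC(=O)CSc3nnc(C)s3)n2-c2ccccc2)cc1` gives 40.6%.

Compound 1 stands highest of the three numbers in this assay. Its nearest neighbour is compound 3, with a step of a number 23.3 percentage points lower from compound 1 to compound 3 (beyond the scatter), and its furthest is compound 2, with a step of a number 26 percentage points lower from compound 1 to compound 2 (beyond the scatter). Between compound 2 and compound 3 the step is a number 2.7 percentage points higher from compound 2 to compound 3 (within the scatter).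

Compound 4 `Cn1nnnc1SCC(=O)N/N=c1/scc(-c2ccccc2)n1-c1ccccc1` is not yet measured. It differs from compound 1 in one place: 1-methyl-1H-tetrazol-5-yl in place of 5-methyl-1,3,4-thiadiazol-2-yl on a sulfur. This change sits on the sulfur attached to the saturated chain carbon, on the side of the shared core away from the phenyl rings where the three measured steps occur. Within the data shown here, both measured steps that leave compound 1 come from chloro or methyl in place of hydrogen on an aromatic carbon, and neither touches the group on the sulfur, so no measured step bears directly on the change to compound 4. With nothing in the data to point one way, the step of a number 3.9 percentage points lower from compound 1 to compound 4 (within the scatter) in this assay is expected to stay within the scatter. Compound 4 is therefore estimated at 60%, in a range from 40% to 80%.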

Compound 4, a percentage reported as activity, at one concentration (the size of the read-out at that concentration, not a potency): 56.2%
Compound 4: middle estimate off by 3.8 percentage points, on the high side; the measured number falls inside the stated range.
By their numbers in this assay, from the lowest: compounds 2 and 3 (each within the scatter of the next); then compounds 4 and 1 (each within the scatter of the next).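

In this assay, among these compounds, this is the first look at the group on the sulfur attached to the saturated chain carbon: putting 1-methyl-1H-tetrazol-5-yl in place of 5-methyl-1,3,4-thiadiazol-2-yl gives a number 7.7 percentage points lower from compound 1 to compound 4 (within the scatter). This change of one five-membered aromatic ring for another, with the same count of heavy atoms and a ring that no longer holds sulfur, therefore stays inside the scatter, whereas the two changes on an aromatic carbon, a number 26 percentage points lower from compound 1 to compound 2 (beyond the scatter) and a number 23.3 percentage points lower from compound 1 to compound 3 (beyond the scatter), lie beyond it. No measurement is at hand that would account for the size of this step.

On these data alone, it remains open whether chloro or methyl in place of hydrogen on an aromatic carbon would give the same steps when 1-methyl-1H-tetrazol-5-yl sits on the sulfur as when 5-methyl-1,3,4-thiadiazol-2-yl does. The compounds shown also leave open what this assay would read with something other than a five-membered aromatic ring on that sulfur, such as a six-membered pyridine ring, a plain ethyl chain or a chain ending in a carboxylic acid.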